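Replacing cyclopropyl with 4-methoxycyclohexyl on compound 1

A few compounds are considered here, and "the series" means these few. Any claim that something is new, unique, unknown or untested is made for them only; others in the source may bear on it.

In an ADME assay on microsomes from liver (Mus musculus) for metabolic stability, read by LC-MS, using NADPH, with a stated time of 10 min, tested at 10 uM (a higher number here means that the compound lasts longer, a lower number that the compound disappears faster), compound 1 `Nc1ncnc2c1c(Oc1cc(C(F)(F)F)ccn1)nn2C1CC1` gives > 2.41 h, which is a limit of the assay and not a number. Its standing in the series rests on (the limit of > 2.41 h in this assay, at which 1 of the 3 values shown sits), so no exact gap to the other compounds can be read. Compound 2 `Nc1ncnc2c1c(Oc1cc(O)ccn1)nn2C1CCC(F)(F)CC1` gives 1.13 h, and compound 3 `Nc1ncnc2c1c(Oc1cccc(C(F)(F)F)c1)nn2[C@H]1C[C@H](O)C1` gives 0.367 h.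

Compound 4 `CO[C@H]1CC[C@H](n2nc(Oc3cc(C(F)(F)F)ccn3)c3c(N)ncnc32)CC1` keeps the rest of compound 1 and has 4-methoxycyclohexyl in place of cyclopropyl on an aromatic nitrogen. Within the data shown here, no measured pair isolates this change. A downward step beyond the usual scatter is nevertheless expected in this assay. This expectation rests on compound 2 at 1.13 h, which also has a six-membered non-aromatic ring of carbon only on an aromatic nitrogen, although it differs from compound 4 elsewhere too. The estimated change is an at least 2.4-fold lower number from compound 1 to compound 4 (0.38 log units; beyond the scatter). For compound 4, the expected half-life is 1 h, with an estimated range of 0.35 h to 2.4 h.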

Compound 4, half-life: 0.217 h
Estimate against measurement, compound 4: 4.6-fold (0.66 log units) above; measured number below the stated range.
By their numbers in this assay, from the lowest: compounds 4 and 3 (each within the scatter of the next); then compound 2. At a limit, above all of these: compound 1.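

With the rest of compound 1 held fixed, 4-methoxycyclohexyl in place of cyclopropyl on an aromatic nitrogen gives, in this assay, an at least 11-fold lower number from compound 1 to compound 4 (1.04 log units; beyond the scatter). Among these compounds, this is the first pair that differs in one place, and it shows that this position alone can move the half-life by a large step, with the trifluoromethyl group left in place. The step has only a minimum size because compound 1 stands at a limit of the assay and not at a number: the limit of > 2.41 h in this assay, at which 1 of the 4 values shown sits.

The compounds shown do not separate the ring size from the methoxy group, which a plain cyclohexyl on the core of compound 1 would do. Among the compounds shown here, whether the same change gives a similar step on another core also rests on no second pair.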